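Phenyl to Pyridin-2-yl: Expected Dose of Compound 3

This account rests on a few compounds, and the source may have more. Where it says the series, first, only, none or still open, it means among the compounds named here.

compound 1 `CC(=O)NN(C)C(=O)NCc1ccccc1`: > 30 mg/kg
compound 2 `CC(=O)NN(C(=O)NCc1ccccc1)c1ccccc1`: > 30 mg/kg

In a functional assay on the whole organism with Mus musculus as the target, in the maximal electroshock model (a higher number here means that more compound is needed for the effect, a lower number that less compound is needed), compound 1 reaches only a limit, > 30 mg/kg. Compound 2 likewise reaches only a limit in this assay, > 30 mg/kg. Among the measured compounds shown here, the one measured step, a step that the two limits leave unreadable from compound 1 to compound 2, therefore cannot be read, since both values sit at the limit of > 30 mg/kg in this assay, at which 2 of the 2 values shown sit. Compound 3 `CC(=O)NN(C(=O)NCc1ccccc1)c1ccccn1` differs from compound 2 by pyridin-2-yl in place of phenyl on an amide-type nitrogen. For the measured compounds named here, no measured step bears on this change, so no direction beyond the scatter can be expected. Compound 3 is expected to give 40 mg/kg, with a range from 15 mg/kg to 150 mg/kg. The expected step that the limit leaves unreadable from compound 2 to compound 3 is an estimate and most likely again only a limit.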

Compound 3, dose for half-maximal effect: < 30 mg/kg
Compound 3 ended at the assay's limit; the forecaster's own chance of this, stated with the estimate: 70%; at least 1.3-fold (0.12 log units) between middle value and limit.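

In this assay, this place on the amide-type nitrogen now shows a difference that methyl and phenyl did not: pyridin-2-yl in place of phenyl gives a number no higher from compound 2 to compound 3 (the limit leaves the size open), and pyridin-2-yl in place of methyl gives a number no higher from compound 1 to compound 3 (the limit leaves the size open). Exchanging one ring carbon for a nitrogen, with the heavy-atom count unchanged, is thus enough to put compound 3 on the other side of the limit, though neither step can be read in size. Nothing measured here gives a reason for this. The compounds shown leave open how far past its limit compound 3 lies, and whether a pyrimidinyl group at this place would behave the same way.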